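The source may report more compounds than this note shows. Statements on the series, on what has been measured and on what is new or still open speak of the compounds shown alone.

Measured compounds in a functional assay on A549 cells (Homo sapiens) for cytotoxicity, read by MTT assay, with a stated time of 48 h; on this read-out higher numbers stand for weaker inhibition and lower numbers for stronger inhibition:
Compound 1, `Cc1cccc(Cn2cc(COc3ccc4c(=O)ccoc4c3)nn2)c1`, gives 20300 nM.
Compound 2, `Cc1ccccc1Cn1cc(COc2ccc3c(=O)ccoc3c2)nn1`, gives only the limit > 100000 nM.
Compound 3, `O=c1ccoc2cc(OCc3cn(Cc4ccccc4Cl)nn3)ccc12`, gives only the limit > 100000 nM.

Compound 3 thus stands at a limit of this assay with no number of its own; this is the limit of > 100000 nM in this assay, at which 2 of the 3 values shown sit. Compound 4, `COc1ccc(Cn2cc(COc3ccc4c(=O)ccoc4c3)nn2)cc1`, differs from compound 3 by 4-methoxyphenyl in place of 2-chlorophenyl on a saturated chain carbon bound to an aromatic nitrogen. The measured steps that touch this position both exchange the ring on the saturated chain carbon bound to the aromatic nitrogen: an at least 4.9-fold higher number from compound 1 to compound 3 (0.69 log units; beyond the scatter) and an at least 4.9-fold higher number from compound 1 to compound 2 (0.69 log units; beyond the scatter). Each moves from 3-methylphenyl to a 2-chlorophenyl or 2-methylphenyl and ends at the limit; between those two limits the step is a step that the two limits leave unreadable from compound 2 to compound 3 and says nothing about its size. Compound 4 carries neither of the two rings that sit at the limit, nor the 3-methylphenyl of compound 1, so a move back toward a readable number is expected, its size uncertain. The expected step is an at least 2.2-fold lower number from compound 3 to compound 4 (0.34 log units; beyond the scatter). Compound 4 is expected to give 45000 nM in this assay, within 15000 nM to 150000 nM, with a real chance of a limit again.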

Compound 4, half-maximal inhibitory concentration: 16500 nM
Compound 4: the middle estimate sits 2.7-fold (0.44 log units) above what was measured, within the range that was stated.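

In this assay, the ring on the saturated chain carbon bound to an aromatic nitrogen now gives a readable number with a second substituent: 4-methoxyphenyl in place of 2-chlorophenyl gives an at least 6.0-fold lower number from compound 3 to compound 4 (0.78 log units; beyond the scatter), and in place of 2-methylphenyl it gives an at least 6.0-fold lower number from compound 2 to compound 4 (0.78 log units; beyond the scatter). Against 3-methylphenyl, 4-methoxyphenyl gives a 1.2-fold lower number from compound 1 to compound 4 (0.09 log units; within the scatter), so these two rings cannot be told apart here. Compound 2 and compound 3, with 2-methylphenyl and 2-chlorophenyl, remain the only compounds at a limit, which is not a number: the limit of > 100000 nM in this assay, at which 2 of the 4 values shown sit.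

The four compounds do not separate the place of a substituent on the ring from its identity; 4-methylphenyl and 3-methoxyphenyl would bear on that. Also open, as far as these compounds go, is how an amine on the ring or a longer chain to the ring would read.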